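Permeability notes on acylurea series, compound 1 to compound 4

The source may report more compounds than this note shows. Statements on the series, on what has been measured and on what is new or still open speak of the compounds shown alone.

Measured so far:
compound 1 `COc1ccccc1C(=O)NC(=O)Nc1ccc(-c2ccccn2)c(C(F)(F)F)c1` 7.4 10^-6 cm/s
compound 2 `COc1ccccc1C(=O)NC(=S)Nc1ccc(N2CCCCC2)c(Cl)c1` 1.8 10^-6 cm/s
compound 3 `COc1ccncc1C(=O)NC(=O)Nc1ccc(-c2ccccc2)c(C(F)(F)F)c1` 2.3 10^-6 cm/s

In an ADME assay on LLC-PK1 cells (Sus scrofa) for permeability (a lower number here means that the compound crosses the layer more slowly, a higher number that the compound crosses the layer faster), compound 1 gives the highest of the three numbers; compound 3 is the nearest, compound 2 the furthest, and both of those gaps lie beyond the scatter. Compound 4 `COc1ccccc1C(=O)NC(=O)Nc1ccc(C(C)C)c(C(F)(F)F)c1` is not yet measured. It differs from compound 1 in one place: isopropyl in place of pyridin-2-yl on an aromatic carbon The group that leaves carries one hydrogen-bond acceptor, the group that enters carries none. For the measured compounds named here, no measured pair in the set shows a change of just this kind, so the size of the step is open. The step from compound 1 to compound 4 is expected to stay small, a 1.2-fold higher number from compound 1 to compound 4 (0.09 log units; within the scatter), within the usual scatter. Compound 4 is estimated at 9 10^-6 cm/s, with a range of 4 10^-6 cm/s to 20 10^-6 cm/s.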

Compound 4, apparent permeability: 2.1 10^-6 cm/s
Compound 4: middle estimate off by 4.3-fold (0.63 log units), on the high side, outside the stated range (below it).
By their numbers in this assay, from the lowest: compounds 2, 4 and 3 (each within the scatter of the next); then compound 1.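

In this assay this position, ortho to a trifluoromethyl group and para to a large group, proves sensitive to the substituent: isopropyl in place of pyridin-2-yl gives a 3.5-fold lower number from compound 1 to compound 4 (0.55 log units; beyond the scatter), a modest step. For the compounds shown here, this is the first single-place comparison, and it shows that the two groups are not interchangeable here. Nothing available accounts for the size of this step.

Still open, from the compounds shown here alone, is how a pyridin-3-yl or a cyclohexyl group at this position would compare with compound 1. Whether the ring, its nitrogen or both matter for this step also remains unresolved.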